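Cytotoxicity notes: halogenated phenylamino series, compound 4 pending

The source may hold more compounds than are shown below. What is called first, only, known or untested is meant among the compounds shown, and "the series" means these compounds.

Measured compounds:
- compound 1 `COC(=O)C1C(C)N=CN1Nc1cccc(Cl)c1`: 107000 nM
- compound 2 `Cc1nc(S)n(Nc2ccc(F)cc2)c1-c1ccccc1`: 220000 nM
- compound 3 `CC1N=C(S)N(Nc2ccccc2)C1C`: 181000 nM

All three were read in a functional assay on MT4 cells (Homo sapiens) for cytotoxicity; on this read-out lower numbers stand for higher toxicity in this test and higher numbers for lower toxicity in this test. Compound 2 gives a higher number than compound 1, a gap beyond the scatter, while compound 3 lies within the scatter of compound 2, so no order between those two can be stated.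

Compound 4 `Cc1nc(S)n(Nc2cccc(Cl)c2)c1-c1ccccc1` has not been measured. It differs from compound 2 by 3-chlorophenyl in place of 4-fluorophenyl on a nitrogen on an aromatic ring. Nothing in the measured set isolates this change, so the expectation rests on the compound 2 value alone: a step of no more than the scatter in either direction, with no preferred direction, is expected for a 1.1-fold lower number from compound 2 to compound 4 (0.04 log units; within the scatter). The estimate for compound 4 in this assay is 200000 nM, expected to fall between 80000 nM and 450000 nM.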

Compound 4, half-maximal cytotoxic concentration: 66700 nM
Compound 4: middle estimate off by 3.0-fold (0.48 log units), on the high side; measured number outside the range, below it.
By their numbers in this assay, from the lowest: compounds 4, 1, 3 and 2 (each within the scatter of the next, the first and the last beyond it).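

On a nitrogen on an aromatic ring, 3-chlorophenyl in place of 4-fluorophenyl gives a 3.3-fold lower number from compound 2 to compound 4 (0.52 log units; beyond the scatter) in this assay. The position therefore responds to the aryl group, even though both groups match in heavy-atom count, donors, acceptors and charge. Nothing available accounts for this step.

The halogen and its place on the phenyl ring change together here, so the compounds shown do not separate the two. Also open, from the compounds shown here alone, is how a phenyl ring carrying an amine or a carboxylic acid would read at this position.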